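Changing the Ring at the End of the Chain

The source may report more compounds than this note shows. Statements on the series, on what has been measured and on what is new or still open speak of the compounds shown alone.

Compound 1 `COc1cc(C(=O)c2cc(OC)c(OC)c(OC)c2)cc(NC(=O)/C=C/c2cc(OC)c(OC)c(OC)c2)c1OC` and compound 2 `COc1cc(C(=O)c2cc(OC)c(OC)c(OC)c2)cc(NC(=O)/C=C/c2ccc(C(F)(F)F)cc2)c1OC` share one core and differ only in the aromatic ring on the double-bonded chain. In a functional assay on ME-180 cells (Homo sapiens) for cytotoxicity, read by MTT assay, with a stated time of 72 h (a lower number here means a stronger inhibitor, a higher number a weaker inhibitor), compound 1 gives 3900 nM, and compound 2 gives 3600 nM; the step of a 1.1-fold lower number from compound 1 to compound 2 (0.03 log units; within the scatter) is within the scatter, so compound 2 stands alongside compound 1 rather than apart from it. Compound 3 `COc1cc(C(=O)c2cc(OC)c(OC)c(OC)c2)cc(NC(=O)/C=C/c2cc(F)c(F)c(F)c2)c1OC` carries the change (3,4,5-trifluorophenyl in place of 4-(trifluoromethyl)phenyl on a double-bonded chain carbon bound to a double-bonded chain carbon). For the measured compounds named here, only that one measured step bears on this change, and it showed no movement beyond the scatter, so compound 3 is expected to stay close to compound 2 in this assay, with an estimate of 3500 nM (range 1500 nM to 8000 nM). The expected step is therefore a 1.0-fold lower number from compound 2 to compound 3 (0.01 log units; within the scatter) for compound 3.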

Compound 3, half-maximal inhibitory concentration: 7100 nM
The estimate for compound 3 lay 2.0-fold (0.31 log units) below the measured number; the measured number falls inside the stated range.
By their numbers in this assay, from the lowest: compounds 2, 1 and 3 (each within the scatter of the next).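

In this assay the steps of a 2.0-fold higher number from compound 2 to compound 3 (0.29 log units; within the scatter) and a 1.8-fold higher number from compound 1 to compound 3 (0.26 log units; within the scatter) show that a third ring on this chain also stays within the scatter of both earlier rings. The 3,4,5-trifluorophenyl, 4-(trifluoromethyl)phenyl and 3,4,5-trimethoxyphenyl groups therefore cannot be ranked at this place. No other measurement here offers an explanation for these numbers. The compounds shown leave open whether a phenyl ring carrying an amine or a carboxylic acid would move the number beyond the scatter. They also leave open what a simple longer carbon chain in place of the ring would do.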